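The source may report more compounds than this note shows. Statements on the series, on what has been measured and on what is new or still open speak of the compounds shown alone.

Values measured in a physicochemical assay for solubility, using the shake flask method, in phosphate buffer, measured as kinetic solubility, with a stated time of 20 h, at pH 6.5 (a lower number here means a less soluble compound, a higher number a more soluble compound), are these
- Compound 1 `FC(F)(F)Oc1ccc(-c2nc3cnc(Nc4ccccn4)cc3[nH]2)cc1` gives < 5000 nM
- Compound 2 `COc1cccnc1Nc1cc2[nH]c(-c3cccc(C(F)(F)F)c3)nc2cn1` gives < 5000 nM
- Compound 3 `Fc1ccc(-c2nc3cnc(Nc4ccccn4)cc3[nH]2)cc1F` gives < 5000 nM

Each of these entries is a limit of the assay and not a number. The evidence therefore comes down to a single bound (the limit of < 5000 nM in this assay, at which 3 of the 3 values shown sit). Compound 2 stands only at a limit (< 5000 nM). No measured number places it relative to compound 1 or compound 3.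

The compound now awaiting measurement is compound 4 `Fc1ccc(Nc2cc3[nH]c(-c4cccc(C(F)(F)F)c4)nc3cn2)nc1`. It is compound 2 with 5-fluoropyridin-2-yl in place of 3-methoxypyridin-2-yl on a nitrogen on an aromatic ring. The rest of the structure is unchanged. Within the data shown here, the set holds no step between two measured compounds, so the size of such a change cannot be read from the data. No shift beyond the usual scatter is expected, in either direction. The expected change is small (a step that the limit leaves unreadable from compound 2 to compound 4) and is only an estimate. Compound 2 is the closest reference, and its reading is a limit (< 5000 nM). A limit is thus the most likely report for compound 4 as well. For compound 4 the estimated solubility is 2500 nM, with an expected range from 500 nM to 5000 nM.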

Compound 4, solubility: < 5000 nM
Compound 4 ended at the assay's limit; the forecaster's own chance of this, stated with the estimate: 85%; the middle value is on the limit's open side.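

In this assay compound 4 gives < 5000 nM, which is a limit of the assay and not a number. Among these compounds, compound 2 also stands at a limit, so no step between compound 2 and compound 4 can be read. The compounds shown leave open the actual solubility of each one, since the evidence is a single bound: the limit of < 5000 nM in this assay, at which 4 of the 4 values shown sit.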